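Compound 3 after a limit value

The source may report more compounds than this note shows. Statements on the series, on what has been measured and on what is new or still open speak of the compounds shown alone.

Compound 1 `COc1ccc(/C=C2\CCC/C(=C\c3ccc(Cl)cc3)C2=O)cc1OC`: 10100 nM
Compound 2 `COc1ccc(/C=C2\CCC/C(=C\c3ccc(Cl)cc3Cl)C2=O)cc1OC`: > 20000 nM

In a functional assay on A549 cells (Homo sapiens) for cytotoxicity, read by MTT assay, with a stated time of 72 h (on this read-out lower numbers stand for stronger inhibition and higher numbers for weaker inhibition), compound 2 gives only a limit, > 20000 nM. Compound 3 `COc1ccc(/C=C2\CCC/C(=C\c3ccc(O)c(Cl)c3)C2=O)cc1OC` differs from it as follows: 3-chloro-4-hydroxyphenyl in place of 2,4-dichlorophenyl on a double-bonded chain carbon bound to a double-bonded ring carbon. Among the compounds with values here, the one measured step that bears on this is an at least 1.9-fold higher number from compound 1 to compound 2 (0.29 log units; that floor lies within the scatter), where chloro replaces hydrogen on an aromatic carbon. Within the data shown here, the expectation therefore leans on compound 1 at 10100 nM, the only number available. The expected change, toward a lower number, is an at least 2.2-fold lower number from compound 2 to compound 3 (0.34 log units; beyond the scatter). Compound 3 is expected at about 9000 nM, with an estimated range from 3000 nM to 20000 nM.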

Compound 3, half-maximal inhibitory concentration: > 20000 nM
Compound 3: only a limit was reported; the forecaster's own chance of this, stated with the estimate: 25%; at least 2.2-fold (0.34 log units) between middle value and limit.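

In this assay compound 3 gives > 20000 nM, which is a limit and not a number. With 3-chloro-4-hydroxyphenyl in place of 4-chlorophenyl, the change gives an at least 1.9-fold higher number from compound 1 to compound 3 (0.29 log units; that floor lies within the scatter), so this second change at the position also yields no readable gain, while the step between the two limits cannot be read. The read-out offers little resolution at this end of the range: the limit of > 20000 nM in this assay, at which 2 of the 3 values shown sit.

On these data alone, the order of compound 2 and compound 3 stays open. So does whether an amine or a carboxylic acid on this aromatic ring would give a measurable value.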